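Resolving the chain stereocentre of a lipoxygenase inhibitor

The source may hold more compounds than are shown below. What is called first, only, known or untested is meant among the compounds shown, and "the series" means these compounds.

Compound 1 `C[C@H](C#Cc1cccc(C(=O)NCCC(c2ccc(F)cc2)c2ccc(C(F)(F)F)cc2)c1)N(O)C(N)=O` gives 220 nM in an assay for inhibition of Polyunsaturated fatty acid 5-lipoxygenase (Homo sapiens), read by HPLC, with stated times of 15 min and 10 min (on this read-out lower numbers stand for stronger inhibition and higher numbers for weaker inhibition), the lowest of the three numbers recorded. Compound 2 `C[C@H](C#Cc1cccc(C(=O)NCCC(c2ccc(F)cc2)c2ccc(OC(F)(F)F)cc2)c1)N(O)C(N)=O`, which carries trifluoromethoxy in place of trifluoromethyl on an aromatic carbon, gives 260 nM; the step of a 1.2-fold higher number from compound 1 to compound 2 (0.07 log units; within the scatter) lies within the scatter. Compound 3 `CC(C#Cc1cccc(C(=O)NCc2ccc(F)cc2C(F)(F)F)c1)N(O)C(N)=O`, with a different amide part, gives 1300 nM, a number well above that of compound 1.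

Compound 4 `C[C@H](C#Cc1cccc(C(=O)NCC[C@H](c2ccc(F)cc2)c2ccc(C(F)(F)F)cc2)c1)N(O)C(N)=O` differs from compound 1 only in drawing: the two compounds have the same atoms and bonds; at least one stereo element is drawn with a configuration in one of them and without one in the other: 1 of 2 stereo elements differ; a stereocentre at a saturated chain carbon is drawn without a configuration in compound 1 and S in compound 4. Within the data shown here, none of the measured steps concerns a stereocentre; the one step available, trifluoromethoxy against trifluoromethyl, was within the scatter. Compound 3 differs from compound 1 in its amide part, not at a stereocentre. Since compound 1 is drawn as an unresolved mixture at that carbon, compound 4 could sit either side of it, and no direction can be read from the data. Compound 4 is therefore expected to give about 200 nM, between 70 nM and 600 nM, a step of a 1.1-fold lower number from compound 1 to compound 4 (0.04 log units; within the scatter) that is expected to stay within the scatter.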

Compound 4, half-maximal inhibitory concentration: 230 nM
The estimate for compound 4 lay 1.2-fold (0.06 log units) below the measured number, within the range that was stated.
By their numbers in this assay, from the lowest: compounds 1, 4 and 2 (each within the scatter of the next); then compound 3.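

In this assay, among these compounds, the step is a 1.0-fold higher number from compound 1 to compound 4 (0.02 log units; within the scatter), the first reading at a stereocentre, since the earlier step concerned only trifluoromethoxy against trifluoromethyl. Compound 4, drawn S at this saturated chain carbon, therefore cannot be told apart from compound 1, drawn there without a configuration. The comparison says nothing of a preference between configurations, and all it rests on is a difference in drawing: the fact that one of compounds 1 and 4 is drawn with a defined configuration and the other without, at the place where they differ

The compounds shown leave open what the R configuration at this carbon would give, and what a change at the second stereocentre, drawn alike in compound 1 and compound 4, would give. They also leave open whether a nitrile or a carboxylic acid in place of trifluoromethyl would give a number like these.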